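This account rests on a few compounds, and the source may have more. Where it says the series, first, only, none or still open, it means among the compounds named here.

Compound 1 `CC(C)(C)OC(=O)NCCCCNCCCN(Cc1ccccc1)Cc1ccccc1`: 12500 nM
Compound 2 `NCCCCNCCCN(Cc1ccccc1)Cc1ccccc1`: 17700 nM
Compound 3 `CC(C)(C)OC(=O)NC1CCC(NCCCN(Cc2ccc(F)cc2)Cc2ccc(F)cc2)CC1`: 4200 nM

In an ADME assay on RAW264.7 cells (Mus musculus) for cytotoxicity, read by resazurin assay, with a stated time of 48 h (on this read-out higher numbers stand for lower toxicity in this test and lower numbers for higher toxicity in this test), compound 1 gives 12500 nM and compound 2 gives 17700 nM. The change between them is hydrogen in place of tert-butoxycarbonyl on an amine nitrogen, and the step is a 1.4-fold higher number from compound 1 to compound 2 (0.15 log units; within the scatter). Compound 3 gives 4200 nM, the lowest of the three numbers; how its core differs from the core of compound 1 is not broken down here.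

Compound 4 `NC1CCC(NCCCN(Cc2ccc(F)cc2)Cc2ccc(F)cc2)CC1` has not been measured. It differs from compound 3 by hydrogen in place of tert-butoxycarbonyl on an amine nitrogen, the same kind of change as from compound 1 to compound 2, though there the amine nitrogen's other neighbour is a saturated chain carbon, while in compound 3 it is a saturated ring carbon. Because a 1.4-fold higher number from compound 1 to compound 2 (0.15 log units; within the scatter) lies within the scatter, a step of similar size is expected here, a 1.3-fold higher number from compound 3 to compound 4 (0.12 log units; within the scatter). Compound 4 is therefore estimated at 5500 nM, likely between 2800 nM and 11000 nM.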

Compound 4, half-maximal cytotoxic concentration: 4400 nM
Compound 4: the middle estimate sits 1.3-fold (0.10 log units) above what was measured; the measured number falls inside the stated range.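

In this assay, putting hydrogen in place of tert-butoxycarbonyl on the amine nitrogen gives a 1.0-fold higher number from compound 3 to compound 4 (0.02 log units; within the scatter). The step on this core cannot be told apart from the one on the earlier core: the same change on two cores in this assay, a 1.4-fold higher number (0.15 log units; within the scatter) from compound 1 to compound 2 and a 1.0-fold higher number (0.02 log units; within the scatter) from compound 3 to compound 4, 1.4-fold (0.13 log units) apart, within the scatter of two such steps. This shows that on these two cores the change carries over with no step beyond the scatter, but it does not show how the change would read on any further core or in any other test.

The compounds shown leave open whether other groups on that amine nitrogen, such as an acetyl group or a methyl group, would also leave the number in this assay within the scatter.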